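This account rests on a few compounds, and the source may have more. Where it says the series, first, only, none or still open, it means among the compounds named here.

The measured compounds:
Compound 1 `C=CC1=C(C(=O)NCCC)C(c2ccc(F)cc2)OC1`: in a functional assay on A549 cells (Homo sapiens) for cytotoxicity, read by MTT assay, with a stated time of 24 h (a lower number here means a stronger inhibitor, a higher number a weaker inhibitor), compound 1 gives > 100000 nM, which is a limit of the assay and not a number.
Compound 2 `C=CC1=C(C(=O)O)C(c2ccc(F)cc2)OC1`: in this assay compound 2 gives > 100000 nM, again only a limit of the assay.
Compound 3 `C=CC1=C(C(=O)NCCCCC)C(c2ccc(Cl)c(Cl)c2)OC1`: in this assay compound 3 gives > 100000 nM, also a limit of the assay.

Compound 1 thus stands nowhere definite on the scale: its value is a limit, and the same holds for the two other compounds, so none of them can be ranked against another. Within the data shown here, the single step between compounds that differ in one place, a step that the two limits leave unreadable from compound 1 to compound 2, is unreadable for that reason, and the one general point that can be drawn is the limit of > 100000 nM in this assay, at which 3 of the 3 values shown sit.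

Compound 4 `C=CC1=C(C(=O)NCc2ccc(Cl)cc2)C(c2ccc(F)cc2)OC1` differs from compound 1 by 4-chlorophenyl in place of ethyl on a saturated chain carbon bound to an amide-type nitrogen. Among the measured compounds shown here, no measured step bears on this change; the only step available concerns another part of the molecule and is itself unreadable. For the measured compounds named here, with every value so far sitting at the limit, the expectation for compound 4 is that it too will most likely return a limit rather than a number. The step in this assay is expected to be a number no higher from compound 1 to compound 4 (the limit leaves the size open). Compound 4 is therefore estimated at 100000 nM, with a range from 30000 nM to 300000 nM.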

Compound 4, half-maximal inhibitory concentration: > 100000 nM
Compound 4: no number, only a limit; the forecaster's own chance of this, stated with the estimate: 80%; the middle value lies on the limit itself.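

Neither compound 1 nor compound 4 gives a number, only a limit, so no step can be read between them, and the same holds for the other compounds: the limit of > 100000 nM in this assay, at which 4 of the 4 values shown sit.

The compounds shown leave open whether any change on the shared core would give a measurable value in this assay, and how large the effect of the propyl to 4-chlorobenzyl change is.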